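Removing the chloro from compound 3: what the edema test may show

A few compounds are considered here, and "the series" means these few. Any claim that something is new, unique, unknown or untested is made for them only; others in the source may bear on it.

Of the compounds shown here, three sharing one core have been measured in a functional assay on the whole organism (strain albino) for inhibition, with Rattus norvegicus as the target, read by paw edema, with stated times of 1 h and 3 h, at a dose of 25 mg/kg by the oral route; on this read-out lower numbers stand for less inhibition and higher numbers for more inhibition at the one dose given (going by the name of the read-out). Compound 1 `CC1=C(C(=O)Nc2ccc(F)cc2)C(c2ccc(Br)cc2)n2c(s/c(=C/c3ccccc3)c2=O)=N1` gives 5%. Compound 2 `CC1=C(C(=O)Nc2ccc(F)cc2)C(c2ccc(Br)cc2)n2c(s/c(=C/c3ccc(Cl)cc3)c2=O)=N1` gives 25%, and compound 3 `CC1=C(C(=O)Nc2ccc(F)cc2)C(c2ccc([N+](=O)[O-])cc2)n2c(s/c(=C/c3ccc(Cl)cc3)c2=O)=N1` gives 23%. On these numbers compound 3 stands second highest of the three: its nearest neighbour is compound 2, within the usual scatter, while compound 1 lies well below it, beyond the scatter. The step of a number 20 percentage points higher from compound 1 to compound 2 (beyond the scatter) is the only one of its kind here; the step of a number 2 percentage points lower from compound 2 to compound 3 (within the scatter) shows that swapping bromo for nitro on the other aromatic ring changed little.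

Compound 4 `CC1=C(C(=O)Nc2ccc(F)cc2)C(c2ccc([N+](=O)[O-])cc2)n2c(s/c(=C/c3ccccc3)c2=O)=N1` differs from compound 3 by hydrogen in place of chloro on an aromatic carbon. This is the mirror image of the change from compound 1 to compound 2, where putting chloro in place of hydrogen on that same aromatic carbon raised the read-out by a modest amount beyond the scatter. Undoing that change is therefore expected to take the read-out back down by a similar amount, and the step of a number 18 percentage points lower from compound 3 to compound 4 (beyond the scatter) is the expected result. The estimate for compound 4 in this assay is 5%, with a range from -5% to 18%.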

Compound 4, a percentage reported as inhibition, in the whole organism at one dose (the size of the read-out at that dose, not a potency): 7%
Estimate against measurement, compound 4: 2 percentage points below, within the range that was stated.
By their numbers in this assay, from the lowest: compounds 1 and 4 (each within the scatter of the next); then compounds 3 and 2 (each within the scatter of the next).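

The chloro effect is not tied to one partner group: in this assay, taking it away gives a number 16 percentage points lower from compound 3 to compound 4 (beyond the scatter), so the change has now been read with a nitro group on the other aromatic ring as well as with a bromo group, and the two readings agree: the same change on two cores in this assay, a number 20 percentage points higher (beyond the scatter) from compound 1 to compound 2 and a number 16 percentage points higher (beyond the scatter) from compound 4 to compound 3, 4 percentage points apart, within the scatter of two such steps

Compound 4 also gives the first test of the bromo-to-nitro swap on the phenyl series, with a number 2 percentage points higher from compound 1 to compound 4 (within the scatter), and this matches the small step already seen on the 4-chlorophenyl series: the same change on two cores in this assay, a number 2 percentage points lower (within the scatter) from compound 2 to compound 3 and a number 2 percentage points higher (within the scatter) from compound 1 to compound 4, 4 percentage points apart, within the scatter of two such steps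

Across these four compounds, the two changes therefore read independently: the read-out follows whether chloro or hydrogen sits on the aromatic carbon, and no compound goes against this, while bromo and nitro remain within the scatter of each other in both pairs.

The compounds shown carry only hydrogen or chloro at this position, so it remains open whether fluoro, methoxy or an amine there would match the chloro compounds. Each number also comes from a single oral dose, which leaves the potency of all four compounds open.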